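The source may hold more compounds than are shown below. What is called first, only, known or untested is meant among the compounds shown, and "the series" means these compounds.

Compound 1 `NS(=O)(=O)CC(=O)NCCSc1nonc1/C(=N/O)Nc1cccc(Cl)c1` is examined in an ADME assay on isolated protein for pharmacokinetics, with UDP-glucuronosyltransferase 1A9 (Homo sapiens) as the target, read by LC-MS, with a stated time of 60 min, at 37 degrees C, tested at 1 uM, in the presence of a further agent that is not named here (on this read-out higher numbers stand for a longer-lived compound and lower numbers for a shorter-lived compound), where compound 1 gives 0.9 h. Among the two plain numbers this is the higher one: compound 3 `NS(=O)(=O)NCCSc1nonc1/C(=N/O)Nc1ccc(F)c(Br)c1` gives 0.183 h, a gap beyond the usual scatter. Compound 2 `C[C@@H](CSc1nonc1/C(=N/O)Nc1ccc(F)c(Br)c1)NC(=O)CS(N)(=O)=O` reaches only a limit of the assay, > 3 h. That single value sits at the limit of > 3 h in this assay, at which 1 of the 3 values shown sits. Compound 4 `N#Cc1cccc(N/C(=N\O)c2nonc2SCCNC(=O)CS(N)(=O)=O)c1` has not been measured yet. It differs from compound 1 in one place: cyano in place of chloro on an aromatic carbon. Among the measured compounds shown here, no pair of measured compounds shows this same change, so its effect is not yet known from the data. The step of a 1.7-fold higher number from compound 1 to compound 4 (0.22 log units; within the scatter) is expected to be modest, leaning toward a longer-lived compound. Compound 4 is estimated at 1.5 h, with a range from 0.6 h to 4 h.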

Compound 4, half-life: > 3 h
Compound 4 ended at the assay's limit; the forecaster's own chance of this, stated with the estimate: 15%; middle value at least 2.0-fold (0.30 log units) away from the limit.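

This position on the ring of compound 1 responds clearly to the swap: cyano in place of chloro gives an at least 3.3-fold higher number from compound 1 to compound 4 (0.52 log units; beyond the scatter), the first measured effect of this change in the set. In this assay compound 4 gives > 3 h, which is a limit and not a number: the limit of > 3 h in this assay, at which 2 of the 4 values shown sit.

Going by these compounds, the true half-life of compound 4 therefore remains open. So does whether an amine or a methoxy group at the same place on the ring would shift the half-life in the same direction.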